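A few compounds are considered here, and "the series" means these few. Any claim that something is new, unique, unknown or untested is made for them only; others in the source may bear on it.

In a functional assay on A549 cells (Homo sapiens) for antiproliferative activity, read by MTT assay, with a stated time of 48 h; a lower number here means a stronger inhibitor, a higher number a weaker inhibitor:
compound 1 `C/C(=C\CC/C(C)=C/CC[C@@H]1[C@@]2(C)CCC(=O)C(C)(C)[C@H]2CC[C@@]1(C)O)CC/C=C(\C)C(=O)OCc1cn(-c2cccc([N+](=O)[O-])c2)nn1`: > 150000 nM (a limit)
compound 2 `C/C(=C\CC/C(C)=C/CC[C@@H]1[C@@]2(C)CCC(=O)C(C)(C)[C@H]2CC[C@@]1(C)O)CC/C=C(\C)C(=O)OCc1cn(-c2cccc(Cl)c2)nn1`: 147000 nM
compound 3 `C/C(=C\CC/C(C)=C/CC[C@@H]1[C@@]2(C)CCC(=O)C(C)(C)[C@H]2CC[C@@]1(C)O)CC/C=C(\C)C(=O)OCc1cn(-c2ccccc2F)nn1`: > 150000 nM (a limit)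

For compound 3 the reading is a limit, > 150000 nM, and not a number. Compound 1 and compound 3 make up (the limit of > 150000 nM in this assay, at which 2 of the 3 values shown sit).

The next change leads to compound 4 `C/C(=C\CC/C(C)=C/CC[C@@H]1[C@@]2(C)CCC(=O)C(C)(C)[C@H]2CC[C@@]1(C)O)CC/C=C(\C)C(=O)OCc1cn(-c2ccc(C(C)(C)C)cc2)nn1`, with 4-(tert-butyl)phenyl in place of 2-fluorophenyl on an aromatic nitrogen.

The measured steps that bear on it all alter the same aryl group: an at least 1.0-fold lower number from compound 1 to compound 2 (0.00 log units; that floor lies within the scatter), an at least 1.0-fold higher number from compound 2 to compound 3 (0.00 log units; that floor lies within the scatter) and a step that the two limits leave unreadable from compound 1 to compound 3. None of them shows a change beyond the scatter, and none of them involves 4-(tert-butyl)phenyl. Among the compounds with values here, compound 2 gives the one reading that is a number, 147000 nM, so the expectation stays close to it.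

No step beyond the scatter is expected in either direction in this assay, and the estimated change is an at least 1.1-fold lower number from compound 3 to compound 4 (0.06 log units; that floor lies within the scatter). A reading that is again only a limit would be no surprise. For compound 4 the estimate is 130000 nM, with an expected range of 60000 nM to 250000 nM.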

Compound 4, half-maximal inhibitory concentration: > 150000 nM
Compound 4: a limit, no number; the forecaster's own chance of this, stated with the estimate: 55%; middle value at least 1.1-fold (0.06 log units) away from the limit.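

In this assay compound 4, with 4-(tert-butyl)phenyl on the aromatic nitrogen, gives > 150000 nM, a limit and not a number. Within the data shown here, the one step with a reading is an at least 1.0-fold higher number from compound 2 to compound 4 (0.00 log units; that floor lies within the scatter), while the steps to compound 4 from compound 1 and from compound 3 cannot be read. An aryl group made of carbon only, with 10 heavy atoms against 7 in 2-fluorophenyl, therefore joins the nitro and fluoro members with no reading beyond the scatter, compound 2 alone giving a number, and the series gathers at one point: the limit of > 150000 nM in this assay, at which 3 of the 4 values shown sit.

Values at a limit cannot rank these aryl groups against one another. Still open, going by these compounds, is whether an amine or a carboxylic acid on the aryl ring, or a longer chain in its place, would bring a reading clearly under this limit.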